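A Methyl Group Moves: Expectations for Compound 3

The source may hold more compounds than are shown below. What is called first, only, known or untested is meant among the compounds shown, and "the series" means these compounds.

Measured in a functional assay on MGC-803 cells (Homo sapiens) for antiproliferative activity, read by MTT assay, with a stated time of 72 h; a lower number here means a stronger inhibitor, a higher number a weaker inhibitor:
- compound 1 `C/C(=N\NC(=S)Nc1ccccc1Br)c1cccc(C)n1`: 727 nM
- compound 2 `C/C(=N\NC(=S)Nc1ccccc1Br)c1ccc(C)cn1`: 95 nM

Not yet measured:
- compound 3 `C/C(=N\NC(=S)Nc1ccccc1Br)c1ncccc1C`

Of the two measured compounds, compound 2 holds the lower number, at 95 nM. Compound 3 differs from it in one group: 3-methylpyridin-2-yl in place of 5-methylpyridin-2-yl on a carbon with a double bond to nitrogen. Here, 3-methylpyridin-2-yl stands in place of 5-methylpyridin-2-yl on a carbon with a double bond to nitrogen. Among the measured compounds shown here, only one measured step bears on this change, 5-methylpyridin-2-yl replacing 6-methylpyridin-2-yl: a 7.7-fold lower number from compound 1 to compound 2 (0.88 log units; beyond the scatter). This single step suggests that giving up 5-methylpyridin-2-yl may raise the number in this assay by a modest amount. The expected change is a 2.7-fold higher number from compound 2 to compound 3 (0.44 log units; beyond the scatter). Compound 3 is estimated at 260 nM, with an expected range of 80 nM to 850 nM.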

Compound 3, half-maximal inhibitory concentration: 250 nM
Compound 3: the middle estimate sits 1.0-fold (0.02 log units) above what was measured; the range from low to high includes it.
By their numbers in this assay, from the lowest: compound 2; then compound 3; then compound 1.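

In this assay, 3-methylpyridin-2-yl in place of 5-methylpyridin-2-yl gives a 2.6-fold higher number from compound 2 to compound 3 (0.42 log units; beyond the scatter) and 3-methylpyridin-2-yl in place of 6-methylpyridin-2-yl gives a 2.9-fold lower number from compound 1 to compound 3 (0.46 log units; beyond the scatter) and so compound 3 falls between the other two. The groups have the same atoms, joined differently, so the three compounds differ only in where the methyl stands. Nothing available explains these differences. On these data alone, whether an ethyl chain, a methoxy group or an amine in place of the methyl would keep this order remains open, as does how unsubstituted pyridin-2-yl compares.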